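The source may report more compounds than this note shows. Statements on the series, on what has been measured and on what is new or still open speak of the compounds shown alone.

Working notes on the series. Of the compounds shown here, three on a shared core have been measured: compound 1 `N=C(NCCCc1c[nH]cn1)NCCC(c1ccc(F)cc1)c1ccccn1`, compound 2 `N=C(NCCCc1c[nH]cn1)NCCC(c1ccc(Cl)cc1)c1ccccn1` and compound 3 `N=C(NCCCc1c[nH]cn1)NCCC(c1ccc(Br)cc1)c1ccccn1`. In a functional assay on ileum for antagonist activity at histamine H1 receptor (Cavia porcellus) (on this read-out higher numbers stand for weaker binding and lower numbers for tighter binding), compound 1 gives 22.4 nM, compound 2 gives 77.6 nM and compound 3 gives 120 nM. Compound 3 therefore stands at the highest of the three numbers; its separation from compound 2 is a 1.5-fold higher number from compound 2 to compound 3 (0.19 log units; within the scatter), whereas the step of a 5.4-fold higher number from compound 1 to compound 3 (0.73 log units; beyond the scatter) and the step of a 3.5-fold higher number from compound 1 to compound 2 (0.54 log units; beyond the scatter) both lie beyond the scatter.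

Compound 4 `N=C(NCCCc1c[nH]cn1)NCCC(c1cccc(F)c1)c1ccccn1` is the next member, not yet measured. The change is 3-fluorophenyl in place of 4-bromophenyl on a saturated chain carbon bound to an aromatic carbon and a saturated chain carbon. Within the data shown here, two measured steps bear on it in part: a 5.4-fold higher number from compound 1 to compound 3 (0.73 log units; beyond the scatter) shows that bromo in place of fluoro raised the number, so the reverse exchange of the halogen should lower it, and a 3.5-fold higher number from compound 1 to compound 2 (0.54 log units; beyond the scatter) points the same way. Among the measured compounds shown here, no measured pair covers the shift of the fluoro within the ring, so that part of the change is open and widens the range. The expected outcome for compound 4 is a 3.0-fold lower number from compound 3 to compound 4 (0.48 log units; beyond the scatter), a lowering beyond the scatter. Compound 4 is estimated in this assay at 40 nM, within a range from 15 nM to 110 nM.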

Compound 4, dissociation constant: 158 nM
Beside the measured number, compound 4's estimate is 4.0-fold (0.60 log units) below it; the measured number lies above the stated range.
By their numbers in this assay, from the lowest: compound 1; then compounds 2, 3 and 4 (each within the scatter of the next, the first and the last beyond it).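

With the halogen kept as fluoro, 3-fluorophenyl in place of 4-fluorophenyl gives a 7.1-fold higher number from compound 1 to compound 4 (0.85 log units; beyond the scatter), so at this saturated chain carbon the read-out depends on where the fluoro sits on the phenyl ring and not only on which halogen is present. The 3-fluorophenyl of compound 4 also gives no advantage over the heavier halogens: a 1.3-fold higher number from compound 3 to compound 4 (0.12 log units; within the scatter) and a 2.0-fold higher number from compound 2 to compound 4 (0.31 log units; beyond the scatter), which leaves the 4-fluorophenyl of compound 1 as the only one of the four set apart from all the others beyond the scatter. No available evidence accounts for this result.

The compounds shown leave open whether the same shift within the ring would count equally for chloro or bromo. They also leave open how a methoxy group, a trifluoromethyl group or an unsubstituted phenyl ring would read at this position.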